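Adding a carbonyl to the tail of compound 2

This account rests on a few compounds, and the source may have more. Where it says the series, first, only, none or still open, it means among the compounds named here.

In a functional assay on K562 cells (Homo sapiens) for inhibition, read by CellTiter-Glo, with a stated time of 48 h (a lower number here means a stronger inhibitor of growth, a higher number a weaker inhibitor of growth), compound 1 (`O=C(CCCCC(=O)N1C/C=C/COCc2cccc(c2)-c2ccnc(n2)Nc2cccc(c2)C1)NO`) gives 4970 nM, compound 2 (`O=C(CCCCN1C/C=C/CCOc2cccc(c2)-c2ccnc(n2)Nc2cccc(c2)C1)NO`) gives 2450 nM and compound 3 (`O=C(CCCCCCN1C/C=C/COCc2cccc(c2)-c2ccnc(n2)Nc2cccc(c2)C1)NO`) gives 940 nM. Compound 2 therefore holds the second highest of the three numbers, with compound 1 above it and compound 3 below it.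

Compound 4 (`O=C(CCCCC(=O)N1C/C=C/CCOc2cccc(c2)-c2ccnc(n2)Nc2cccc(c2)C1)NO`) is not yet measured. It keeps the core of compound 2 and has (4-(hydroxycarbamoyl)butyl)carbonyl in place of 4-(hydroxycarbamoyl)butyl on an amine nitrogen in a ring.

Within the data shown here, the one measured step that bears on this is modest: a 5.3-fold lower number from compound 1 to compound 3 (0.72 log units; beyond the scatter). That step removes the same carbonyl-bearing group, so it runs the opposite way, but it installs 6-(hydroxycarbamoyl)hexyl and sits on a different core. Only part of it can be expected to carry over. A higher number is expected in this assay, near the level of compound 1 at 4970 nM.

The estimated change is a 2.0-fold higher number from compound 2 to compound 4 (0.31 log units; beyond the scatter). The expected value for compound 4 is 5000 nM, within an estimated range of 2200 nM to 11500 nM.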

Compound 4, concentration for 50% growth inhibition: 1440 nM
Estimate against measurement, compound 4: 3.5-fold (0.54 log units) above; measured number below the stated range.
By their numbers in this assay, from the lowest: compounds 3, 4 and 2 (each within the scatter of the next, the first and the last beyond it); then compound 1.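

On the core of compound 2, the carbonyl on the ring amine nitrogen is tolerated in this assay: the change gives a 1.7-fold lower number from compound 2 to compound 4 (0.23 log units; within the scatter), so this step does not separate the two tails. The earlier step at this nitrogen, a 5.3-fold lower number from compound 1 to compound 3 (0.72 log units; beyond the scatter), changed the carbonyl and the chain together, whereas this pair changes the tail by the carbonyl on a single core. The carbonyl alone therefore does not reproduce the size of that earlier step on the core of compound 2, and no data at hand bear on the reason for this result.

As far as these compounds go, whether the tolerance holds with a longer chain carrying the carbonyl on this core remains open. Also open, from the compounds shown here alone, is whether a sulfonyl group on the ring nitrogen would read the same as the carbonyl.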